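This account rests on a few compounds, and the source may have more. Where it says the series, first, only, none or still open, it means among the compounds named here.

Three compounds share one core and differ only in the aryl group on the five-membered ring. Compound 1 `COc1cc(-n2c(-c3ccccc3)csc2=S)cc(OC)c1OC` carries a plain phenyl; in a functional assay on MCF7 cells (Homo sapiens) for cytotoxicity, read by MTT assay, with a stated time of 48 h (on this read-out lower numbers stand for stronger inhibition and higher numbers for weaker inhibition), compound 1 reaches only the limit of > 100 ug/mL. Compound 2 `COc1cc(-n2c(-c3ccc(Cl)cc3)csc2=S)cc(OC)c1OC` adds a single chloro, and in this assay compound 2 likewise stops at the limit of > 100 ug/mL. Within the data shown here, compound 3 `COc1cc(-n2c(-c3ccc(Cl)cc3Cl)csc2=S)cc(OC)c1OC` stands apart: in this assay compound 3 gives 23.6 ug/mL, the only real number among the three. The step of an at least 4.2-fold lower number from compound 2 to compound 3 (0.62 log units; beyond the scatter) and the step of an at least 4.2-fold lower number from compound 1 to compound 3 (0.62 log units; beyond the scatter) both show the dichlorinated aryl pulling the number down, while the step that the two limits leave unreadable from compound 1 to compound 2 cannot be read because both values sit at the limit of > 100 ug/mL in this assay, at which 2 of the 3 values shown sit.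

Compound 4 `COc1cc(-n2c(-c3ccc(C)cc3)csc2=S)cc(OC)c1OC` reverses that direction: 4-methylphenyl in place of 2,4-dichlorophenyl on an aromatic carbon. Among the measured compounds shown here, both chlorines that distinguished compound 3 from compound 1 and compound 2 are gone, and a methyl stands where no measured compound carried one, so that part of the change has no precedent here. The two readable steps point toward a higher number once the chlorines leave. Compound 4 is therefore expected to show the step of a 3.8-fold higher number from compound 3 to compound 4 (0.58 log units; beyond the scatter). Compound 4 is estimated at 90 ug/mL, within 35 ug/mL to 200 ug/mL, with a fair chance that only a limit is reported.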

Compound 4, half-maximal inhibitory concentration: 19.7 ug/mL
The estimate for compound 4 lay 4.6-fold (0.66 log units) above the measured number; measured number below the stated range.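

In this assay, the step of a 1.2-fold lower number from compound 3 to compound 4 (0.08 log units; within the scatter) leaves 4-methylphenyl and 2,4-dichlorophenyl level at this place next to the ring nitrogen, so a measurable number here does not depend on the two chlorines of compound 3. The step of an at least 5.0-fold lower number from compound 2 to compound 4 (0.70 log units; beyond the scatter) shows that a single group on the phenyl can be enough, and that methyl and chloro do not behave alike in this assay, while the step of an at least 5.0-fold lower number from compound 1 to compound 4 (0.70 log units; beyond the scatter) shows methyl in place of hydrogen having an effect that the unreadable step for chloro in place of hydrogen cannot show for chloro. These two new steps give only a minimum size, and the steps between limits cannot be read, as compound 1 and compound 2 both stay at a limit: the limit of > 100 ug/mL in this assay, at which 2 of the 4 values shown sit.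

The compounds shown leave open whether an ethyl group or a longer chain in the place of that methyl would keep the number of compound 4. They also leave open whether a methoxy group or an amine there would follow compound 4 or fall back to the limit of compound 2.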